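A few compounds are considered here, and "the series" means these few. Any claim that something is new, unique, unknown or untested is made for them only; others in the source may bear on it.

Three compounds share one core and differ only in the group carried on a saturated ring carbon. Compound 1 `Cc1cc(O)c(C2=NN(c3ccc(S(N)(=O)=O)cc3)C(c3ccccc3Cl)C2)cc1Cl` carries a 2-chlorophenyl group there, compound 2 `Cc1cc(O)c(C2=NN(c3ccc(S(N)(=O)=O)cc3)C(/C=C/c3ccccc3)C2)cc1Cl` a 2-phenylethenyl group, and compound 3 `COc1ccc(C2CC(c3cc(Cl)c(C)cc3O)=NN2c2ccc(S(N)(=O)=O)cc2)cc1OC` a 3,4-dimethoxyphenyl group. All three were tested in a functional assay on MDA-MB-468 cells (Homo sapiens) for antiproliferative activity, with a stated time of 48 h; on this read-out higher numbers stand for lower toxicity in this test and lower numbers for higher toxicity in this test. Compound 1 reaches only a limit of the test, > 100000 nM. Compound 3 likewise gives only a limit, > 100000 nM. Among the compounds with values here, compound 2 gives 37200 nM, the one real number among the three, and so it is the point from which everything else is read. The step of an at least 2.6-fold lower number from compound 1 to compound 2 (0.42 log units; beyond the scatter) is beyond the scatter. the limit of > 100000 nM in this assay, at which 2 of the 3 values shown sit, marks where the two limits sit.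

Compound 4 `COc1ccc(C2CC(c3cc(Cl)c(C)cc3O)=NN2c2ccc(S(N)(=O)=O)cc2)c(OC)c1OC` has not been tested. It differs from compound 2 in one place: 2,3,4-trimethoxyphenyl in place of 2-phenylethenyl on a saturated ring carbon. Within the data shown here, the closest precedent is the step of an at least 2.6-fold higher number from compound 2 to compound 3 (0.42 log units; beyond the scatter), where a methoxy-bearing phenyl ring in place of the 2-phenylethenyl group moved the number back toward the limit. A similar move is therefore expected here, with a 2.7-fold higher number from compound 2 to compound 4 (0.43 log units; beyond the scatter). Compound 4 is estimated at 100000 nM, within 40000 nM to 300000 nM, with a fair chance that only a limit is reported.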

Compound 4, concentration lethal to 50% of the cells: > 100000 nM
Compound 4: no number, only a limit; the forecaster's own chance of this, stated with the estimate: 65%; the middle value sits exactly at the limit.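

The step of an at least 2.6-fold higher number from compound 2 to compound 4 (0.42 log units; beyond the scatter) shows that compound 3 is not alone: a second methoxy-bearing phenyl ring on this saturated ring carbon, here 2,3,4-trimethoxyphenyl, also lacks the measurable effect seen with 2-phenylethenyl. In this assay compound 4 gives only a limit of the test, > 100000 nM. The steps from compound 1 and from compound 3 to compound 4 cannot be read, so nothing can be said about what the extra methoxy in place of hydrogen on an aromatic carbon does, and compound 2 remains the only one of the series with a real number, while the others gather at one value: the limit of > 100000 nM in this assay, at which 3 of the 4 values shown sit.

Still open, as far as these compounds go, is whether a 2-phenylethyl chain, which keeps the phenyl ring of compound 2 but lacks its double bond, would also give a real number in this assay. Equally open is how a small group such as an amine or a carboxylic acid would behave on this same ring carbon, since every group shown here carries a six-membered aromatic ring.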